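A few compounds are considered here, and "the series" means these few. Any claim that something is new, unique, unknown or untested is made for them only; others in the source may bear on it.

Working notes on the series in a functional assay on the whole organism (strain albino) for inhibition, with Rattus norvegicus as the target, read by paw edema, with a stated time of 2 h, at a dose of 0.28 mmol/kg by the oral route; on this read-out lower numbers stand for less inhibition and higher numbers for more inhibition at the one dose given (going by the name of the read-out).

Two compounds carry numbers. Compound 1 `C=CCn1c(SCC(=O)c2ccccc2)nnc1-c1ccc(OC)c(OC)c1` gives 63% in this assay. Compound 2 `C=CCn1c(SC/C(=N/O)c2ccccc2)nnc1-c1cc(OC)c(OC)c(OC)c1` gives 68% in this assay. Within the data shown here, compound 2 and compound 1 stand within the usual scatter of each other, so the two numbers cannot be told apart on this read-out; no step between them counts as a change.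

Compound 3 `C=CCn1c(SCC(=O)c2ccccc2)nnc1-c1cc(OC)c(OC)c(OC)c1` has not yet been measured in this assay. It differs from compound 2 by a group of 8 heavy atoms (7 carbon, 1 oxygen; one six-membered aromatic ring of carbon only) in place of a group of 9 heavy atoms (7 carbon, 1 nitrogen, 1 oxygen; one six-membered aromatic ring of carbon only), on a saturated chain carbon bound to a sulfur. The benzoyl that enters in compound 3 is the same group that compound 1 carries on the saturated chain carbon bound to a sulfur, and compound 1 sits within the scatter of compound 2.

Among the measured compounds shown here, with no measured step that separates the two known compounds, no change beyond the scatter is expected from compound 2 to compound 3; the expected step is a number 3 percentage points lower from compound 2 to compound 3 (within the scatter). Compound 3 is expected to give about 65% in this assay, with a range from 52% to 76%.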

Compound 3, a percentage reported as inhibition, in the whole organism at one dose (the size of the read-out at that dose, not a potency): 62%
Estimate against measurement, compound 3: 3 percentage points above; the measured number falls inside the stated range.
By their numbers in this assay, from the lowest: compounds 3, 1 and 2 (each within the scatter of the next).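

In this assay, among these compounds, benzoyl in place of the group of 9 heavy atoms (7 carbon, 1 nitrogen, 1 oxygen), on a saturated chain carbon bound to a sulfur, gives a number 6 percentage points lower from compound 2 to compound 3 (within the scatter), the first step that can be read at this place; on this read-out, at the one dose given, the two groups cannot be told apart. Among the compounds shown here, compound 3 also gives the first step at a second place: methoxy in place of hydrogen on an aromatic carbon gives a number 1 percentage points lower from compound 1 to compound 3 (within the scatter), so this change likewise leaves the read-out within the scatter, and the three compounds now form a set in which neither single change registers. Nothing available bears on why these numbers lie so close together.

Going by these compounds, both groups compared at the saturated chain carbon carry a six-membered aromatic ring of carbon only, so it stays open whether a carboxylic acid, an amine or a longer chain at that place would give a step beyond the scatter. On these data alone, since the read-out is the size of the effect at one dose and not a potency, differences between these compounds at other doses also stay open.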